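The source may hold more compounds than are shown below. What is called first, only, known or untested is meant among the compounds shown, and "the series" means these compounds.

Working notes on the series.

The series shares the core seen in compound 1 `O[C@@H]1Cc2ccccc2[C@H]1NC1CCN(CCCc2c[nH]c3ccc(-n4cnnc4)cc23)CC1` and compound 2 `COC[C@H](NC1CCN(CCCc2c[nH]c3ccc(Cn4cncn4)cc23)CC1)c1ccc(F)cc1`. In an assay on CHO cells for displacement of a labelled ligand from 5-hydroxytryptamine receptor 1D (Homo sapiens) (on this read-out higher numbers stand for weaker inhibition and lower numbers for stronger inhibition), compound 1 gives 6.6 nM, and in this assay compound 2 gives 5 nM. Of the two numbers recorded, compound 1 has the higher one, but the two values sit within the usual scatter of each other, so nothing separates them.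

Compound 3 `c1cncc(CNC2CCN(CCCc3c[nH]c4ccc(-n5cnnc5)cc34)CC2)c1` has not been measured in this assay. It differs from compound 1 in one place: (pyridin-3-yl)methyl in place of 2-hydroxy-2,3-dihydro-1H-inden-1-yl on an amine nitrogen. The group that leaves carries a hydrogen-bond donor and two defined stereocentres; the group that enters carries neither, so the change removes the defined stereochemistry at that amine substituent. Among the measured compounds shown here, no measured pair shows this kind of exchange, so its effect cannot be read from the data.

The expectation is that the step from compound 1 to compound 3 in this assay is a modest one toward a higher number, of about a 2.3-fold higher number from compound 1 to compound 3 (0.36 log units; beyond the scatter), and it may not exceed the scatter. Compound 3 is estimated at 15 nM, with a range from 4 nM to 60 nM.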

Compound 3, half-maximal inhibitory concentration: 35 nM
The estimate for compound 3 lay 2.3-fold (0.37 log units) below the measured number; the measured number falls inside the stated range.
By their numbers in this assay, from the lowest: compounds 2 and 1 (each within the scatter of the next); then compound 3.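

Among the compounds shown here, on the amine nitrogen, (pyridin-3-yl)methyl in place of 2-hydroxy-2,3-dihydro-1H-inden-1-yl gives, in this assay, a 5.3-fold higher number from compound 1 to compound 3 (0.72 log units; beyond the scatter), the first single-place change to be read. Compound 1 and compound 2 differ in more than one place, so they could not show that the read-out responds to the substituent at this position. The exchange removes the hydrogen-bond donor and both defined stereocentres and leaves fewer heavy atoms, but these differences travel together in this one pair, and no measurement shown bears on what lies behind the step.

Going by these compounds, it remains open whether 2,3-dihydro-1H-inden-1-yl without its hydroxyl, or a plain benzyl, on the same amine nitrogen would give a number closer to that of compound 1 or to that of compound 3, which would begin to separate the part played by the hydroxyl from that of the ring nitrogen of the pyridine. On these data alone, the mirror-image form of the 2-hydroxy-2,3-dihydro-1H-inden-1-yl group also remains open, so the role of its stereochemistry cannot be judged.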